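Opening the ring of compound 2 to a dipropylamino group

The source may report more compounds than this note shows. Statements on the series, on what has been measured and on what is new or still open speak of the compounds shown alone.

Measured in an ADME assay on microsomes from liver (Rattus norvegicus) for metabolic stability, read by LC-MS, using NADPH, at 37 degrees C; a higher number here means that the compound lasts longer, a lower number that the compound disappears faster:
Compound 1 `Cc1ccccc1-c1nc(CN2CCC(C(=O)NCCCN3CC(C)(C)CC(C)(C)C3)CC2)c(C)o1` gives 0.095 h
Compound 2 `Cc1ccccc1-c1nc(CN2CCC(C(=O)NCCN3C[C@H](C)C[C@H](C)C3)CC2)c(C)o1` gives > 0.5 h (a limit, not a number)

Compound 2 stands at the limit of > 0.5 h in this assay, at which 1 of the 2 values shown sits, so its place is known only as a limit. Compound 3 `CCCN(CCC)CCNC(=O)C1CCN(Cc2nc(-c3ccccc3C)oc2C)CC1` has not yet been measured. It differs from compound 2 by dipropylamino in place of 3,5-dimethylpiperidin-1-yl on a saturated chain carbon, two bonds along the chain from an amide-type nitrogen, which leaves no ring in that group. Within the data shown here, only one measured step bears on this, and only loosely: an at least 5.2-fold higher number from compound 1 to compound 2 (0.72 log units; beyond the scatter). Compound 1 and compound 2 both carry a ring in this group, so that step gives no direct measure of losing it. On that thin basis, a modest fall in this assay is expected, with an at least 1.4-fold lower number from compound 2 to compound 3 (0.15 log units; that floor lies within the scatter) as the estimated step. Compound 3 is estimated at 0.35 h, within an expected range of 0.12 h to 0.9 h, for this read-out.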

Compound 3, half-life: > 0.5 h
Compound 3: only a limit was reported; the forecaster's own chance of this, stated with the estimate: 35%; middle value at least 1.4-fold (0.15 log units) from the limit.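

In this assay compound 3 gives > 0.5 h, which is a limit and not a number, and it joins compound 2 there: the limit of > 0.5 h in this assay, at which 2 of the 3 values shown sit. The step from compound 2 to compound 3 cannot be read, but it shows that a ring in this group is not required to reach the limit, since dipropylamino, with no ring, reaches it as well. Compound 3 also keeps the distance from the earlier compound, with an at least 5.2-fold higher number from compound 1 to compound 3 (0.72 log units; beyond the scatter).

As far as these compounds go, how far compound 2 and compound 3 actually lie apart, and how much longer either lasts, remains open. Also open, from the compounds shown here alone, is how a morpholine or a diethylamino group would fare on a saturated chain carbon, two bonds along the chain from an amide-type nitrogen.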